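The compounds below may be only part of what the source reports. "The series", "measured", "known", "first", "only" and "open" are said of these compounds alone.

The series rests on a shared core, carried by compound 1 `O=C(/C=C1\CCc2ccc(F)cc21)NCCO`, compound 2 `NC(=O)/C=C1\CCc2cc(F)cc(F)c21` and compound 3 `NC(=O)/C=C1\CCc2ccc(Br)cc21`, and read in a functional assay on the whole organism with Rattus norvegicus as the target, at a dose of 20 mg/kg by the oral route; on this read-out higher numbers stand for more inhibition at the one dose given (going by the name of the read-out) and lower numbers for less inhibition. Compound 1 gives 78%, the highest of the three numbers. Its nearest neighbour is compound 2, which in this assay gives 55%, a gap beyond the scatter. The furthest is compound 3, which in this assay gives 21%, also beyond the scatter. Among the measured compounds shown here, none of these three compounds differs from another in only one place, so no single step between measured compounds is available.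

Compound 4 `O=C(/C=C1\CCc2ccc(F)cc21)NC1CCC1` is not yet measured. It differs from compound 1 by cyclobutyl in place of 2-hydroxyethyl on an amide-type nitrogen: the 2-hydroxyethyl group leaves and cyclobutyl enters, on the amide-type nitrogen whose other neighbour is the carbonyl carbon. For the measured compounds named here, no measured pair shows this change, so the expectation for compound 4 in this assay rests on compound 1 alone, and a moderate step downward, beyond the scatter, is expected. The step from compound 1 to compound 4 is estimated at a number 20 percentage points lower from compound 1 to compound 4 (beyond the scatter). Compound 4 is expected to give 58%, within a range from 30% to 85%.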

Compound 4, a percentage reported as inhibition, in the whole organism at one dose (the size of the read-out at that dose, not a potency): 0%
Compound 4: middle estimate off by 58 percentage points, on the high side; measured number outside the range, below it.
By their numbers in this assay, from the lowest: compound 4; then compound 3; then compound 2; then compound 1.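

Among the compounds shown here, on the amide-type nitrogen of the shared core, cyclobutyl in place of 2-hydroxyethyl gives the first step that changes one place only: in this assay the read-out is a number 78 percentage points lower from compound 1 to compound 4 (beyond the scatter) with the rest of the structure unchanged. For the compounds shown here, this shows that the group on this nitrogen can on its own decide much of the read-out at this dose, something the earlier compounds could not show, as they differ in more than one place. No measurement here accounts for the size of this step.

The change removes the hydroxyl and the open chain together and brings in a ring, so the compounds shown do not separate these parts. Going by these compounds, an ethyl, 2-methoxyethyl or 2-aminoethyl group on the same nitrogen would test each part, and whether the step carries over to other ring substituents also remains open.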